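The compounds below may be only part of what the source reports. "The series", "measured", "known", "first", "only" and "open" are said of these compounds alone.

Measured so far:
compound 1, `O=C(Nc1nnc(-c2ccc(O)c(O)c2)s1)c1ccc(Cl)cc1`, a functional assay on HL-60 cells (Homo sapiens) for cytotoxicity, read by MTT assay, with a stated time of 72 h; a higher number here means a weaker inhibitor, a lower number a stronger inhibitor: 14700 nM
compound 2, `CC(=O)Nc1nnc(-c2cccc(O)c2O)s1`, this assay: 49000 nM

Compound 1 gives the lower of the two numbers measured in this assay; compound 2 stands higher, by a gap stated to lie beyond the usual scatter. For the measured compounds named here, the two compounds differ in more than one place, so no single step between them is counted, and nothing more is drawn from that pair.

Compound 3, `Cc1ccc(C(=O)Nc2nnc(-c3ccc(O)c(O)c3)s2)cc1`, has not been measured in this assay. It differs from compound 1 by methyl in place of chloro on an aromatic carbon. Going by the values given here, only one measured pair is in hand, and it does not isolate this change, so no measured step informs the expectation. A change of this kind is expected to move the number little, in either direction, most likely not beyond the scatter. The expected step from compound 1 to compound 3 is a 1.2-fold higher number from compound 1 to compound 3 (0.09 log units; within the scatter). Compound 3 is therefore estimated at 18000 nM, within a range of 7000 nM to 45000 nM.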

Compound 3, half-maximal inhibitory concentration: 10500 nM
Estimate against measurement, compound 3: 1.7-fold (0.23 log units) above; low and high end bracket the measured number.
By their numbers in this assay, from the lowest: compounds 3 and 1 (each within the scatter of the next); then compound 2.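

In this assay, for the compounds shown here, the exchange of 4-chlorophenyl to 4-methylphenyl supplies the first step that isolates one place: a 1.4-fold lower number from compound 1 to compound 3 (0.15 log units; within the scatter). On this aromatic carbon, para to a large group, chloro and methyl are therefore not separated by this read-out, which the earlier pair of compounds, differing in more than one place, could not show. Nothing measured here bears on why these two groups read alike.

From the compounds shown here alone, whether an amine, a carboxylic acid or a longer chain on the same carbon would stand apart from chloro and methyl remains open. Also open, going by these compounds, is what plain hydrogen would give there, and so whether any group at this position affects the number in this assay.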